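Changing a nitrogen substituent at the assay limit

The compounds below may be only part of what the source reports. "The series", "measured", "known", "first", "only" and "open" are said of these compounds alone.

In a functional assay on HCT-116 cells (Homo sapiens) for cytotoxicity, read by MTT assay, with a stated time of 72 h (on this read-out lower numbers stand for stronger inhibition and higher numbers for weaker inhibition), compound 2 (`CN(C)CCCNc1c(C(=O)NCc2ccc(F)cc2)nc(Br)c2cccnc12`) gives > 10000 nM, which is a limit of the assay and not a number. Compound 1 (`Nc1cccc(Nc2c(C(=O)NCc3ccc(F)cc3)nc(Br)c3cccnc23)c1`) gives > 10000 nM, which is also only a limit. All that is known so far is therefore (the limit of > 10000 nM in this assay, at which 2 of the 2 values shown sit).

Compound 3 (`C[C@H](Nc1c(C(=O)NCc2ccc(F)cc2)nc(Br)c2cccnc12)c1ccccc1`) differs from compound 2 in one place: 1-phenylethyl in place of 3-(dimethylamino)propyl on a nitrogen on an aromatic ring. Put simply, 1-phenylethyl stands in place of 3-(dimethylamino)propyl on a nitrogen on an aromatic ring.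

Among the measured compounds shown here, only one measured step bears on this change, and it altered the group on the same nitrogen: a step that the two limits leave unreadable from compound 1 to compound 2. It offers no size to carry over and no direction to follow. Neither substituent measured so far has brought a value inside the range of this assay, so compound 3 is expected to sit near the limit as well. The expected step is a step that the limit leaves unreadable from compound 2 to compound 3, an estimate with no firm direction. For compound 3 the estimated value is 12000 nM, with an expected range from 5000 nM to 30000 nM.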

Compound 3, half-maximal inhibitory concentration: > 20000 nM
Compound 3 was reported as a limit; the forecaster's own chance of this, stated with the estimate: 75%; middle value at least 1.6-fold (0.22 log units) away from the limit.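

Among the compounds shown here, compound 3, like compound 1 and compound 2, is reported only as a limit of the assay and not as a number, and no step of any size can be read between these three compounds. The compounds shown leave open which group on this nitrogen, if any, would bring a value inside the range of this assay.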